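Trading a chlorophenyl ring for furan on the shared core

The source may hold more compounds than are shown below. What is called first, only, known or untested is meant among the compounds shown, and "the series" means these compounds.

In a functional assay on SK-MEL-2 cells (Homo sapiens) for cytotoxicity, read by sulforhodamine B assay, with a stated time of 2 days, tested at 100 uM (on this read-out higher numbers stand for more inhibition at the one concentration tested (going by the name of the read-out) and lower numbers for less inhibition), compound 2 `O=C(Nn1c(-c2cccc([N+](=O)[O-])c2)nc2c(-c3ccc(Cl)cc3)n[nH]c2c1=O)c1ccccc1` gives 89%, the higher of the two numbers measured. Compound 1 `CCCc1n[nH]c2c(=O)n(NC(=O)c3ccccc3)c(-c3cccc([N+](=O)[O-])c3)nc12` gives 22.9%. Within the data shown here, the single measured step is a number 66.1 percentage points higher from compound 1 to compound 2 (beyond the scatter), so a flat ring in this place was worth far more than a chain. Compound 3 `O=C(Nn1c(-c2cccc([N+](=O)[O-])c2)nc2c(-c3ccco3)n[nH]c2c1=O)c1ccccc1` differs from compound 2 in one place: furan-2-yl in place of 4-chlorophenyl on an aromatic carbon. Among the measured compounds shown here, a ring stays, but a smaller one, and no measured step shows this exact swap. A moderate drop is expected, a number 29 percentage points lower from compound 2 to compound 3 (beyond the scatter), leaving compound 3 expected at 60%, within a wide range of 25% to 90%.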

Compound 3, a percentage reported as inhibition, at one concentration (the size of the read-out at that concentration, not a potency): 23%
Estimate against measurement, compound 3: 37 percentage points above, outside the stated range (below it).
By their numbers in this assay, from the lowest: compounds 1 and 3 (each within the scatter of the next); then compound 2.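

In this assay, a ring at this aromatic carbon is not enough on its own: the change to furan-2-yl gives a number 66 percentage points lower from compound 2 to compound 3 (beyond the scatter) and wipes out what 4-chlorophenyl had added. With a number 0.1 percentage points higher from compound 1 to compound 3 (within the scatter) as the other step, furan-2-yl and propyl cannot be told apart here, so among these three groups only 4-chlorophenyl stands out. No available evidence explains this difference. Still open, from the compounds shown here alone, is whether the high number depends on the six-membered ring or on its chlorine. A plain phenyl group at this position would separate the two.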